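This account rests on a few compounds, and the source may have more. Where it says the series, first, only, none or still open, it means among the compounds named here.

Measured in a functional assay on SK-OV-3 cells (Homo sapiens) for inhibition, read by CCK-8 assay, with a stated time of 70 h; on this read-out lower numbers stand for stronger inhibition and higher numbers for weaker inhibition:
- compound 1 `COc1ccc(OCCOCCNC2CCCC2)cc1`: 99100 nM
- compound 2 `c1ccc(COc2ccc(OCCOCCOC3CCCC3)cc2)cc1`: > 100000 nM
- compound 3 `c1ccc(COc2ccc(COc3ccc(OCCOCCNC4CCCCC4)cc3)cc2)cc1`: 8080 nM

Compound 2 reports only a limit of the assay, not a number: the limit of > 100000 nM in this assay, at which 1 of the 3 values shown sits.

Of the two true numbers in this assay, compound 1 has the higher, at 99100 nM. Compound 3 is lower at 8080 nM, a gap beyond the usual scatter.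

Compound 4 `Nc1ccccc1COc1ccc(OCCOCCNC2CCCC2)cc1` keeps the core of compound 1 and makes one change: 2-aminophenyl in place of hydrogen on a saturated chain carbon bound to an oxygen on an aromatic ring. The methoxy of compound 1 thus becomes (2-aminobenzyl)oxy.

Among the compounds with values here, no pair of measured compounds differs in one place only, so the size of this step has no direct precedent. The best guide is compound 3, which also carries a larger group at that end and gives 8080 nM, though it differs from compound 1 in more than one place. Compound 2 also carries a larger group there and goes against this reading.

A moderate step towards stronger inhibition, beyond the scatter, is therefore expected in this assay. The estimated change is a 4.0-fold lower number from compound 1 to compound 4 (0.60 log units; beyond the scatter).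

For compound 4 the expected value is 25000 nM, with an estimated range of 7000 nM to 90000 nM.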

Compound 4, half-maximal inhibitory concentration: 14000 nM
Estimate against measurement, compound 4: 1.8-fold (0.25 log units) above; measured number inside the range.
By their numbers in this assay, from the lowest: compounds 3 and 4 (each within the scatter of the next); then compound 1. At a limit, above all of these: compound 2.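

In this assay, the saturated chain carbon bound to an oxygen on an aromatic ring accepts 2-aminophenyl in place of hydrogen, and the change gives a 7.1-fold lower number from compound 1 to compound 4 (0.85 log units; beyond the scatter). Within the data shown here, this is the first pair that differs in one place only, so it is also the first direct reading of a change at this position: going from methoxy to (2-aminobenzyl)oxy on an otherwise unchanged core is enough on its own to move the read-out beyond the scatter. Nothing measured in the series accounts for the size of this step or ties it to any property of the entering group.

On these data alone, it remains open whether the step depends on the amine or on the added ring alone: a plain benzyl, a 2-hydroxybenzyl or a 2-cyanobenzyl on the core of compound 1 would separate the two. Also open, as far as these compounds go, is whether the step carries over to a different amine end, such as a piperidine or a morpholine in place of the cyclopentylamine.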